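A few compounds are considered here, and "the series" means these few. Any claim that something is new, unique, unknown or untested is made for them only; others in the source may bear on it.

Compound 1 `CCCn1c(=O)[nH]c2nc(-c3ccc(S(=O)(=O)N4CCN(Cc5ccc(Br)cc5)CC4)cc3)[nH]c2c1=O` gives > 1000 nM in an assay on CHO cells for displacement of a labelled ligand from adenosine receptor A1 (Homo sapiens), read by scintillation counting, with a stated time of 90 min, in the presence of a further agent that is not named here (on this read-out lower numbers stand for stronger inhibition and higher numbers for weaker inhibition), which is a limit of the assay and not a number.
Compound 2 `CCCn1c(=O)[nH]c2nc(-c3ccc(S(=O)(=O)N4CCN(c5ccccc5Cl)CC4)cc3)[nH]c2c1=O` gives > 1000 nM in this assay, again a limit rather than a number.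
Compound 3 `CCCn1c(=O)[nH]c2nc(-c3ccc(S(=O)(=O)N4CCN(c5ccccc5)CC4)cc3)[nH]c2c1=O` gives 364 nM in this assay.

Going by the values given here, compound 3 therefore holds the only measured number in this set; the other two values sit at the limit of > 1000 nM in this assay, at which 2 of the 3 values shown sit. The step from compound 1 to compound 3 is an at least 2.7-fold lower number from compound 1 to compound 3 (0.43 log units; beyond the scatter), and the step from compound 2 to compound 3 is an at least 2.7-fold lower number from compound 2 to compound 3 (0.43 log units; beyond the scatter), while a step that the two limits leave unreadable from compound 1 to compound 2.

Compound 4 `CCCn1c(=O)[nH]c2nc(-c3ccc(S(=O)(=O)N4CCN(c5cccc(Cl)c5)CC4)cc3)[nH]c2c1=O` differs from compound 3 by chloro in place of hydrogen on an aromatic carbon. The measured step that bears on this change is the one in which hydrogen replaced chloro, an at least 2.7-fold lower number from compound 2 to compound 3 (0.43 log units; beyond the scatter), the reverse of the present change, though there the chloro sat on 2-chlorophenyl rather than 3-chlorophenyl. Adding chloro back is thus expected to raise the number, by a modest amount at most, with a real chance that only a limit is returned.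

Compound 4 is expected to give about 750 nM, within 250 nM to 2200 nM. The expected step is a 2.1-fold higher number from compound 3 to compound 4 (0.31 log units; beyond the scatter).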

Compound 4, inhibition constant: > 1000 nM
Compound 4 gave a limit, no number (the forecaster's own chance of this, stated with the estimate: 35%); middle value at least 1.3-fold (0.12 log units) away from the limit.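

In this assay, 3-chlorophenyl in place of phenyl gives an at least 2.7-fold higher number from compound 3 to compound 4 (0.43 log units; beyond the scatter), so the loss seen earlier with chloro on 2-chlorophenyl is not confined to that one placing of the chloro. Compound 2 and compound 4 each give a limit, so the steps among compound 1, compound 2 and compound 4 cannot be read, and neither chloro placing can be ranked against the other. The plain phenyl of compound 3 remains the only group here that returns a number: the limit of > 1000 nM in this assay, at which 3 of the 4 values shown sit.

Going by these compounds, the true size of the loss remains open, as does whether it belongs to chloro itself or would follow any group added to this phenyl. A fluoro atom or a methoxy group in place of the chloro would help to separate those two readings.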